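A few compounds are considered here, and "the series" means these few. Any claim that something is new, unique, unknown or untested is made for them only; others in the source may bear on it.

In a functional assay on LOX IMVI cells (Homo sapiens) (on this read-out higher numbers stand for lower toxicity in this test and lower numbers for higher toxicity in this test), compound 1 `Cc1ccc(S(=O)(=O)n2c(C3(O)C=CC(=O)C=C3)cc3ccccc32)cc1` gives 230 nM, while compound 2 `Cc1ccc(S(=O)(=O)n2c(C3(O)C=CC(=O)c4ccccc43)cc3ccccc32)cc1` gives 720 nM. Compound 1 therefore holds the lower of the two numbers, and the gap between them lies beyond the usual scatter of repeated measurements. This makes compound 1 the more toxic of the pair in this test. Compound 3 `COc1ccc(S(=O)(=O)n2c(C3(O)C=CC(=O)C=C3)cc3ccccc32)cc1`, not yet measured, keeps the core of compound 1 and changes a single group: methoxy in place of methyl on an aromatic carbon, para to a large group (methoxy in place of methyl on an aromatic carbon). For the measured compounds named here, no measured pair shows this kind of change, so the size of the step cannot be read from the data. The best anchor is compound 1 at 230 nM, and no step beyond the scatter is expected in either direction in this assay. The estimated move is a 1.1-fold higher number from compound 1 to compound 3 (0.04 log units; within the scatter). For compound 3, the expected value is 250 nM, with an estimated range from 110 nM to 550 nM.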

Compound 3, concentration lethal to 50% of the cells: 380 nM
Estimate against measurement, compound 3: 1.5-fold (0.18 log units) below, and the stated range covers the measured number.
By their numbers in this assay, from the lowest: compounds 1, 3 and 2 (each within the scatter of the next, the first and the last beyond it).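

For the compounds shown here, this is the first measured swap at this spot, on an aromatic carbon para to a large group. In this assay, going from 4-methylphenyl to 4-methoxyphenyl gives a 1.7-fold higher number from compound 1 to compound 3 (0.22 log units; within the scatter), so on this read-out the two groups cannot be told apart here, even though methoxy brings an oxygen and a hydrogen-bond acceptor that methyl lacks. Nothing else measured here offers an explanation for this result.

As far as these compounds go, it remains open whether a more different group at the same spot, such as an amine, a carboxylic acid or a longer chain, would produce a step beyond the scatter. From the compounds shown here alone, it is also open whether methoxy in place of methyl would read the same way on the core of compound 2.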